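The source may report more compounds than this note shows. Statements on the series, on what has been measured and on what is new or still open speak of the compounds shown alone.

Compounds measured in a functional assay on SK-OV-3 cells (Homo sapiens) for antiproliferative activity, read by sulforhodamine B assay, with a stated time of 72 h; on this read-out lower numbers stand for stronger inhibition and higher numbers for weaker inhibition:
- compound 1, `Clc1ccc(C(/C=C/c2ccccc2)=N\Nc2nncc3ccccc23)cc1`: 0.07 nM
- compound 2, `NC(=S)NNc1nncc2ccccc12`: 0.8 nM
- compound 3, `Cc1cc(NS(=O)(=O)c2ccc(Nc3nncc4ccccc34)cc2)no1`: 6.7 nM

All three share the same core, and compound 3 stands with the highest number of the three on this read-out. Its nearest neighbour is compound 2, whose number lies well beyond the scatter below it, and compound 1 lies further still, with the lowest number of the set.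

Compound 4, `NS(=O)(=O)c1ccc(Nc2nncc3ccccc23)cc1`, has not been measured. It differs from compound 3 in one place only: hydrogen in place of 5-methyl-1,2-oxazol-3-yl on a sulfonamide nitrogen. Among the compounds with values here, no measured pair in this set isolates such a change, so nothing directly shows its effect. Because compound 3 gives 6.7 nM and the rest of the molecule is kept, a modest step is expected, most likely towards a somewhat higher number, though a step within the scatter is quite possible. The expected step is a 2.2-fold higher number from compound 3 to compound 4 (0.35 log units; beyond the scatter). Compound 4 is therefore estimated at 15 nM, with a likely range from 3 nM to 60 nM.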

Compound 4, half-maximal inhibitory concentration: 0.8 nM
Estimate against measurement, compound 4: 19-fold (1.27 log units) above, outside the stated range (below it).
By their numbers in this assay, from the lowest: compound 1; then compounds 2 and 4 (each within the scatter of the next); then compound 3.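

In this assay, replacing the 5-methyl-1,2-oxazol-3-yl group on the sulfonamide nitrogen with hydrogen gives an 8.4-fold lower number from compound 3 to compound 4 (0.92 log units; beyond the scatter), a step beyond the scatter. Within the data shown here, this is the first direct reading of this position, and it shows that the 5-methyl-1,2-oxazol-3-yl group is not required for a low number on this read-out, since the form carrying only hydrogen there has the lower number of the pair. Nothing at hand bears on why the number moves in this direction.

Going by these compounds, whether a small group such as methyl or acetyl on that nitrogen would give a number closer to that of compound 4 or of compound 3 remains open. So does whether another ring there, such as phenyl or pyridin-2-yl, would behave like the 5-methyl-1,2-oxazol-3-yl group.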